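The source may hold more compounds than are shown below. What is called first, only, known or untested is meant among the compounds shown, and "the series" means these compounds.

Compound 1 `O[C@H](COCCOC[C@@H](O)Cc1cn(Cc2ccc3ccccc3c2)nn1)Cc1ccc(-c2ccccc2)cc1` gives 8600 nM in a functional assay on HCT-116 cells (Homo sapiens) for inhibition, read by MTT assay, with a stated time of 72 h; a higher number here means a weaker inhibitor of growth, a lower number a stronger inhibitor of growth. Compound 2 `CC1=C(CCCCCCCCCCn2cc(C[C@H](O)COCCOC[C@@H](O)Cc3ccc(-c4ccccc4)cc3)nn2)C(=O)c2ccccc2C1=O` gives 3000 nM in this assay.

Of these two numbers, compound 1 has the higher one, and the gap to compound 2 lies beyond the scatter. Compound 3 `O[C@H](COCCOC[C@@H](O)Cc1cn(-c2ccc3c(c2)OCCO3)nn1)Cc1ccc(-c2ccccc2)cc1` differs from compound 1 only in one place: 2,3-dihydro-1,4-benzodioxin-6-yl in place of (naphthalen-2-yl)methyl on an aromatic nitrogen. Among the compounds with values here, no measured pair shows this kind of change, so its effect cannot be read from the data. Compound 3 is expected to stay close to compound 1, with the step of a 1.2-fold higher number from compound 1 to compound 3 (0.07 log units; within the scatter) estimated as small, in either direction. For compound 3 the estimate is 10000 nM, in the range 3000 nM to 30000 nM.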

Compound 3, concentration for 50% growth inhibition: 16500 nM
Compound 3: middle estimate off by 1.7-fold (0.22 log units), on the low side; the range from low to high includes it.
By their numbers in this assay, from the lowest: compound 2; then compounds 1 and 3 (each within the scatter of the next).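

In this assay the exchange of (naphthalen-2-yl)methyl for 2,3-dihydro-1,4-benzodioxin-6-yl on an aromatic nitrogen gives a 1.9-fold higher number from compound 1 to compound 3 (0.28 log units; within the scatter) and so shows that this position accepts the change without a shift beyond the scatter. The entering group carries 2 hydrogen-bond acceptors and the leaving group none, yet the two compounds cannot be told apart here. Nothing measured bears on why this is so. Going by these compounds, whether an amine or a carboxylic acid on this nitrogen would move the number beyond the scatter stays open.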